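Compound 3 to compound 4: ethoxy in place of methyl

A few compounds are considered here, and "the series" means these few. Any claim that something is new, unique, unknown or untested is made for them only; others in the source may bear on it.

In a functional assay on FM3A cells (Mus musculus) for antiproliferative activity, with a stated time of 48 h (on this read-out lower numbers stand for stronger inhibition and higher numbers for weaker inhibition), compound 3 `Cc1ccc(C(=O)/C=C/c2ccc(N)cc2)cc1` gives 107000 nM and sits within the scatter of compound 2 `Nc1ccc(/C=C/C(=O)c2ccc(F)cc2)cc1` at 185000 nM but far from compound 1 `C=C(Br)C(=O)Nc1ccc(/C=C/C(=O)c2ccc(OCC)cc2)cc1` at 680 nM on the same read-out. Compound 4 `CCOc1ccc(C(=O)/C=C/c2ccc(N)cc2)cc1` differs from compound 3 by ethoxy in place of methyl on an aromatic carbon with ethoxy in place of methyl on an aromatic carbon para to a large group. For the measured compounds named here, compound 1 also carries ethoxy but differs elsewhere too, so it offers no clean step. Going by the values given here, with a 1.7-fold lower number from compound 2 to compound 3 (0.24 log units; within the scatter) as the one measured step at this aromatic carbon, no step beyond the scatter is expected in this assay for this swap. The expected step is a 1.1-fold lower number from compound 3 to compound 4 (0.05 log units; within the scatter) and stays within the scatter. For compound 4 the estimated value is 95000 nM with an expected range of 40000 nM to 220000 nM overall.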

Compound 4, half-maximal inhibitory concentration: 55000 nM
For compound 4 the middle estimate is 1.7-fold (0.24 log units) above the measured one; the range from low to high includes it.
By their numbers in this assay, from the lowest: compound 1; then compounds 4, 3 and 2 (each within the scatter of the next, the first and the last beyond it).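

In this assay, ethoxy on this aromatic carbon stays within the scatter of methyl (a 1.9-fold lower number from compound 3 to compound 4 (0.29 log units; within the scatter)), yet it is separated from fluoro by a modest step (a 3.4-fold lower number from compound 2 to compound 4 (0.53 log units; beyond the scatter)). With ethoxy held fixed, hydrogen in place of (1-bromoethenyl)carbonyl on the nitrogen gives a much larger step (an 81-fold higher number from compound 1 to compound 4 (1.91 log units; beyond the scatter)), so the nitrogen substituent outweighs the swaps on this carbon among these compounds. No measurement here explains either step.

Going by these compounds, whether (1-bromoethenyl)carbonyl gives a similar step alongside methyl or fluoro remains open. So does the effect of a longer chain such as butoxy, or of an amine, on this carbon.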